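Pentamethoxy-chromone series: a further methoxy on the pendant ring

The compounds below may be only part of what the source reports. "The series", "measured", "known", "first", "only" and "open" are said of these compounds alone.

Measured compounds:
compound 1 `COc1ccc(-c2cc(=O)c3c(OC)c(OC)c(OC)c(OC)c3o2)c(OC)c1`, 15 ug/mL
compound 2 `COc1cc2c(=O)cc(-c3ccc(O)cc3)oc2c(OC)c1OC`, 0.7 ug/mL
compound 3 `COc1cc(OC)cc(-c2cc(=O)c3c(OC)c(OC)c(OC)c(OC)c3o2)c1`, 3 ug/mL

In a functional assay on KB cells (Homo sapiens) for cytotoxicity (a lower number here means that less compound is needed, a higher number that more compound is needed for the effect), compound 1 gives 15 ug/mL, compound 2 gives 0.7 ug/mL and compound 3 gives 3 ug/mL. Compound 3 therefore stands second highest of the three numbers; the nearest is compound 2, whose number is lower by more than the scatter, and the furthest is compound 1, whose number is higher by more than the scatter. Compound 2 differs from the other two in both rings, so nothing in its gap to compound 3 can be tied to one change.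

Compound 4 `COc1cc(-c2cc(=O)c3c(OC)c(OC)c(OC)c(OC)c3o2)cc(OC)c1OC` has not yet been measured in this assay. Relative to compound 3 the change is methoxy in place of hydrogen on an aromatic carbon. Among the measured compounds none of the pairs is separated by a single change, so no step of this kind is on record to lean on. The expected step is small: a 1.5-fold lower number from compound 3 to compound 4 (0.18 log units; within the scatter), leaning to a slightly lower number, but not far beyond the scatter. For compound 4 the estimate in this assay is 2 ug/mL, with a range from 0.6 ug/mL to 8 ug/mL.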

Compound 4, concentration for half-maximal effect: 0.5 ug/mL
Compound 4: middle estimate off by 4.0-fold (0.60 log units), on the high side, and the stated range ends above it.
By their numbers in this assay, from the lowest: compounds 4 and 2 (each within the scatter of the next); then compound 3; then compound 1.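

Among these compounds, the step from hydrogen to methoxy is the first single change on record: in this assay it gives a 6.0-fold lower number from compound 3 to compound 4 (0.78 log units; beyond the scatter) and so provides a direct reading of one position. This aromatic carbon, ortho to two methoxy groups and para to a large group, is therefore sensitive to substitution, and with methoxy there, less compound is needed for the effect. No measurement at hand explains the size of this step.

The compounds shown do not tell whether this shift is particular to methoxy, since hydrogen and methoxy are the only two groups compared at this carbon; an amine or an ethoxy group there would test that. On these data alone, whether the same change has a similar effect on a different substitution pattern of the shared core also remains open.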